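This account rests on a few compounds, and the source may have more. Where it says the series, first, only, none or still open, it means among the compounds named here.

Going by the values given here, compound 2 `C(=N/Nc1nc2ccccc2s1)\c1ccc(Oc2ccccc2)cc1` gives 5.2 in a physicochemical assay for lipophilicity, in phosphate buffer, measured as octanol-water partition, with a stated time of 24 h (on this read-out higher numbers stand for higher lipophilicity and lower numbers for lower lipophilicity), the lower of the two numbers measured so far. Compound 1 `Cc1cc(Oc2ccc(/C=N/Nc3nc4ccccc4s3)cc2)ccc1Cl` gives 5.5 in this assay. Among the compounds with values here, the only measured step, a number 0.30 log units lower from compound 1 to compound 2 (within the scatter), removed both a chloro and a methyl from the ring on the oxygen and stayed within the scatter.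

Compound 3 `Clc1ccc(Oc2ccc(/C=N/Nc3nc4ccccc4s3)cc2)cc1` is not yet measured. It differs from compound 2 by chloro in place of hydrogen on an aromatic carbon. The step from compound 1 to compound 2 is the only one that bears on this change, and it reverses part of it: compound 3 restores the chloro of compound 1 but not the methyl. Given that a number 0.30 log units lower from compound 1 to compound 2 (within the scatter) was small, the change is expected to raise the number by a small amount, at most slightly beyond the scatter, a number 0.40 log units higher from compound 2 to compound 3 (beyond the scatter). Compound 3 is therefore expected to give 5.6, within 5.2 to 6.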

Compound 3, partition coefficient: 5.6
Beside the measured number, compound 3's estimate shows no gap at the digits printed, within the range that was stated.
By their numbers in this assay, from the lowest: compounds 2, 1 and 3 (each within the scatter of the next, the first and the last beyond it).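

Taken alone, chloro in place of hydrogen on the six-membered aromatic ring, para to a large group, gives a number 0.40 log units higher from compound 2 to compound 3 (beyond the scatter) in this assay and is the first step in the series to lie beyond the scatter. Hydrogen in place of methyl on an aromatic carbon gives a number 0.10 log units higher from compound 1 to compound 3 (within the scatter) and so leaves compound 1 and compound 3 indistinguishable on this read-out, which means the chloro step can be read here while the methyl step cannot be separated from the scatter. The data hold no measurement that accounts for either step.

As far as these compounds go, whether another group at this place, such as fluoro, methoxy, an amine or a carboxylic acid, would shift the number beyond the scatter remains open. Also open, from the compounds shown here alone, is whether chloro elsewhere on this ring would give a step of similar size.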